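A few compounds are considered here, and "the series" means these few. Any claim that something is new, unique, unknown or untested is made for them only; others in the source may bear on it.

- compound 1 `O=C(CC1Oc2cc(O)ccc2C=C1c1ccc(O)cc1)c1ccccc1`: 102000 nM
- compound 2 `Cc1ccc(C(=O)CC2Oc3cc(O)ccc3C=C2c2ccc(O)cc2)cc1`: 60000 nM
- compound 3 `CCc1ccc(C(=O)CC2Oc3cc(O)ccc3C=C2c2ccc(O)cc2)cc1`: 377000 nM

These three compounds were tested in a functional assay on SHEP cells (Homo sapiens) for antiproliferative activity, read by spectrophotometry and resazurin assay, with a stated time of 72 h; on this read-out lower numbers stand for stronger inhibition and higher numbers for weaker inhibition. Compound 2 gives 60000 nM, the lowest number of the three, but its lead is not clear-cut. The data show a 1.7-fold lower number from compound 1 to compound 2 (0.23 log units; within the scatter), whereas they also show a 6.3-fold higher number from compound 2 to compound 3 (0.80 log units; beyond the scatter).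

Compound 4 `O=C(CC1Oc2cc(O)ccc2C=C1c1ccc(O)cc1)c1ccc(Cl)cc1` keeps the shared core and has chloro in place of methyl on an aromatic carbon, para to a large group: chloro in place of methyl on an aromatic carbon. In other words, 4-methylphenyl becomes 4-chlorophenyl. Going by the values given here, no measured step makes this exact swap, so the nearest evidence comes from changes at the same place. Adding methyl to compound 1 gave a step within the scatter, a 1.7-fold lower number from compound 1 to compound 2 (0.23 log units; within the scatter), while adding ethyl gave a modest one, a 3.7-fold higher number from compound 1 to compound 3 (0.57 log units; beyond the scatter). Chloro replaces methyl atom for atom, so the smaller of these steps seems the better guide, and no shift beyond the scatter is expected. The expected result is a 1.3-fold higher number from compound 2 to compound 4 (0.12 log units; within the scatter). For compound 4 the estimated value is 80000 nM, with an expected range from 30000 nM to 250000 nM.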

Compound 4, half-maximal inhibitory concentration: 167000 nM
The estimate for compound 4 lay 2.1-fold (0.32 log units) below the measured number; the measured number falls inside the stated range.
By their numbers in this assay, from the lowest: compounds 2, 1 and 4 (each within the scatter of the next, the first and the last beyond it); then compound 3.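

In this assay, the swap from 4-methylphenyl to 4-chlorophenyl gives a 2.8-fold higher number from compound 2 to compound 4 (0.44 log units; beyond the scatter) and so lies beyond the scatter, which shows that methyl and chloro are not interchangeable at this position, even though they are alike in size by heavy-atom count. Chloro in place of hydrogen gives a 1.6-fold higher number from compound 1 to compound 4 (0.21 log units; within the scatter) and chloro in place of ethyl gives a 2.3-fold lower number from compound 3 to compound 4 (0.35 log units; beyond the scatter), so of the groups shown, only ethyl is set apart from hydrogen by a step beyond the scatter. Nothing available explains why these groups differ.

As far as these compounds go, whether a fluoro group, a methoxy group, an amine or a longer chain such as propyl would sit with hydrogen, methyl and chloro or with ethyl remains open. From the compounds shown here alone, all four compounds vary at this one position, so the effect of changes elsewhere on the shared core also remains open.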